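Swapping a hydroxyethyl group for a larger ring group

A few compounds are considered here, and "the series" means these few. Any claim that something is new, unique, unknown or untested is made for them only; others in the source may bear on it.

Values in an ADME assay for permeability; on this read-out higher numbers stand for higher permeability and lower numbers for lower permeability:
- Compound 1 `CC(=O)Nc1c(F)cc(C(=O)N[C@H]2CC[C@H](O)CC2)cc1O[C@@H](C)c1ccccc1`: 17 nm/s
- Compound 2 `CNC(=O)c1cc(C(=O)NC2CC2)n(Cc2ccccc2)n1`: > 80 nm/s (a limit of the assay, not a number)
- Compound 3 `CNC(=O)c1cc(C(=O)NCCO)n([C@@H](C)c2ccccc2)n1`: 59 nm/s

Only two of these results are actual numbers. Compound 3 gives the higher of them at 59 nm/s, and compound 1 sits lower at 17 nm/s, a gap beyond the usual scatter of repeated measurements.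

Compound 4 `CNC(=O)c1cc(C(=O)N[C@H]2[C@@H]3C[C@@H](O)C[C@@H]32)n([C@@H](C)c2ccccc2)n1` differs from compound 3 in one place, on an amide-type nitrogen: a group of 7 heavy atoms (6 carbon, 1 oxygen; one three-membered non-aromatic ring of carbon only, one five-membered non-aromatic ring of carbon only) in place of a group of 3 heavy atoms (2 carbon, 1 oxygen; no ring), on an amide-type nitrogen. In words, a group of 7 heavy atoms with a three-membered and a five-membered ring takes the place of the 2-hydroxyethyl.

Among the measured compounds shown here, no measured pair shows what such a swap does in this assay, so the other compounds give only weak guidance. Compound 1 also has a ring of carbon only on an amide-type nitrogen, and it gives 17 nm/s. Compound 2 has such a ring too, and its result of > 80 nm/s is a limit. These two compounds point in opposite directions, so no clear direction can be expected. The expected change, a 1.1-fold lower number from compound 3 to compound 4 (0.03 log units; within the scatter), is an estimate that stays within the scatter. Compound 4 is estimated at 55 nm/s, with an expected range of 25 nm/s to 110 nm/s.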

Compound 4, apparent permeability: 61 nm/s
Beside the measured number, compound 4's estimate is 1.1-fold (0.04 log units) below it; measured number inside the range.
By their numbers in this assay, from the lowest: compound 1; then compounds 3 and 4 (each within the scatter of the next). At a limit, above all of these: compound 2.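

Replacing the 2-hydroxyethyl on the amide-type nitrogen with the larger group carrying a three-membered and a five-membered ring gives a 1.0-fold higher number from compound 3 to compound 4 (0.01 log units; within the scatter) in this assay. Among the compounds shown here, this is the first measured change at this place, and it shows that, on this core, the read-out of this assay stays within the scatter when the group grows from an open chain to a two-ring group with 4 defined stereocentres and the same counts of hydrogen-bond donors and acceptors. The only limit among the results belongs to compound 2, which gives a limit of the assay and not a number: the limit of > 80 nm/s in this assay, at which 1 of the 4 values shown sits.

This single pair cannot show whether the hydroxyl of either group matters, since no group shown on this nitrogen lacks one except the cyclopropyl of compound 2, which differs from compound 3 in more than one place. It also leaves open how a group of another kind on the same nitrogen, such as an amine or a carboxylic acid, would read in this assay.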